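The source may report more compounds than this note shows. Statements on the series, on what has been measured and on what is new or still open speak of the compounds shown alone.

Compound 1 `Cc1ccc(C(CCN(C)C)NC(=O)C#Cc2ccccc2)cc1` and compound 2 `Cc1ccc(C(CCN(C)C)NC(=O)CCc2ccccc2)cc1` share one core. In a functional assay on NIH3T3 cells for agonist activity at Urotensin-2 receptor (Homo sapiens), with a stated time of 5 days (a lower number here means that less compound is needed, a higher number that more compound is needed for the effect), compound 1 gives 3090 nM, and compound 2 gives 4570 nM; the change between them is phenethyl in place of 2-phenylethynyl on a carbonyl carbon, and the step is a 1.5-fold higher number from compound 1 to compound 2 (0.17 log units; within the scatter). Compound 3 `CN(C)CCC(NC(=O)C#Cc1ccccc1)c1ccc2ccccc2c1` carries a different core; the difference between the two cores is not broken down here. In this assay compound 3 gives 457 nM, the lowest of the three numbers, compound 1 standing nearest to it. Compound 4 `CN(C)CCC(NC(=O)CCc1ccccc1)c1ccc2ccccc2c1` is not yet measured. It differs from compound 3 by phenethyl in place of 2-phenylethynyl on a carbonyl carbon, the same change as from compound 1 to compound 2, at a place described in the same words. Because the step of a 1.5-fold higher number from compound 1 to compound 2 (0.17 log units; within the scatter) lay within the scatter, the expected step is a 1.5-fold higher number from compound 3 to compound 4 (0.18 log units; within the scatter). Compound 4 is therefore estimated at 690 nM, between 300 nM and 1600 nM.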

Compound 4, half-maximal effective concentration: 603 nM
Compound 4: middle estimate off by 1.1-fold (0.06 log units), on the high side; measured number inside the range.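

In this assay, phenethyl in place of 2-phenylethynyl on a carbonyl carbon gives a 1.3-fold higher number from compound 3 to compound 4 (0.12 log units; within the scatter), and the change reads the same on both cores: the same change on two cores in this assay, a 1.5-fold higher number (0.17 log units; within the scatter) from compound 1 to compound 2 and a 1.3-fold higher number (0.12 log units; within the scatter) from compound 3 to compound 4, 1.1-fold (0.05 log units) apart, within the scatter of two such steps

On these two cores, then, the step carries over from one core to the other, and on neither can it be told apart from no change at all. This does not show that the two groups are equivalent, nor that the step would stay as small on any other core in the series.

Open, on these data alone, is whether a longer chain or a carboxylic acid in place of phenethyl would shift the number beyond the scatter. Also open, as far as these compounds go, is whether such a replacement would read the same on both cores.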